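Swapping the amide linker for a branched pyridylethyl group

A few compounds are considered here, and "the series" means these few. Any claim that something is new, unique, unknown or untested is made for them only; others in the source may bear on it.

Compound 2 `Cc1ccc(C(=O)c2nc(NC(=O)c3cccnc3)nc3ccsc23)s1` gives the lowest number of the two compounds measured in a functional assay on CHO-K1 cells for antagonist activity at adenosine receptor A2b (Homo sapiens), read by FLIPR and calcium flux (a higher number here means a weaker inhibitor, a lower number a stronger inhibitor), namely 287 nM, while compound 1 `Cc1ccc(C(=O)c2nc(NCc3ccccc3)nc3ccsc23)s1` gives 5580 nM. Compound 3 `Cc1ccc(C(=O)c2nc(NC(C)c3ccccn3)nc3ccsc23)s1` has not yet been measured; (1-(pyridin-2-yl)ethyl in place of (pyridin-3-yl)carbonyl on a nitrogen on an aromatic ring). Among the measured compounds shown here, the only step that bears on this change is a 19-fold lower number from compound 1 to compound 2 (1.29 log units; beyond the scatter), where a carbonyl-linked pyridine replaced a benzyl group. Compound 3 removes that carbonyl again and returns to an aryl group joined through a saturated carbon, so a shift back toward the weaker number of compound 1 is expected, estimated as an 8.7-fold higher number from compound 2 to compound 3 (0.94 log units; beyond the scatter). Compound 3 is therefore expected to give 2500 nM in this assay, within a range of 600 nM to 9000 nM.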

Compound 3, half-maximal inhibitory concentration: 19 nM
For compound 3 the middle estimate is 130-fold (2.12 log units) above the measured one, outside the stated range (below it).
By their numbers in this assay, from the lowest: compound 3; then compound 2; then compound 1.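

The carbonyl is not required at this place on the nitrogen: in this assay, 1-(pyridin-2-yl)ethyl outperforms (pyridin-3-yl)carbonyl (a 15-fold lower number from compound 2 to compound 3 (1.18 log units; beyond the scatter)). Both of the groups joined through a saturated carbon are now covered, and they differ widely (a 290-fold lower number from compound 1 to compound 3 (2.47 log units; beyond the scatter)), so a saturated link does not by itself give a weak inhibitor. Nothing available explains these differences. Benzyl and 1-(pyridin-2-yl)ethyl differ in both the ring nitrogen and the branching methyl, so their separate contributions remain open. A pyridin-2-ylmethyl group or a 1-phenylethyl group would separate them.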